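A few compounds are considered here, and "the series" means these few. Any claim that something is new, unique, unknown or untested is made for them only; others in the source may bear on it.

In an ADME assay on PBMC cells (Homo sapiens) for cytotoxicity, with a stated time of 72 h (on this read-out higher numbers stand for weaker inhibition and lower numbers for stronger inhibition), compound 1 `O=C(NO)c1cc(F)c(Cn2nnc(-c3ccco3)n2)c(F)c1` gives > 1000 nM, which is a limit of the assay and not a number. Compound 2 `Nc1ccc(-c2nnn(Cc3c(F)cc(C(=O)NO)cc3F)n2)cc1` gives > 1000 nM, which is also only a limit. Among the compounds with values here, the one measured step is a step that the two limits leave unreadable from compound 1 to compound 2, so it offers no size to carry forward. Within the data shown here, the only evidence is the limit of > 1000 nM in this assay, at which 2 of the 2 values shown sit. Compound 3 `O=C(NO)c1cc(F)c(Cn2nnc(-c3ccccn3)n2)c(F)c1` has pyridin-2-yl in place of 4-aminophenyl on an aromatic carbon. No step beyond the scatter is therefore expected in this assay. The estimated step is a step that the limit leaves unreadable from compound 2 to compound 3. Compound 3 is expected at 2000 nM, with an estimated range of 800 nM to 10000 nM.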

Compound 3, half-maximal inhibitory concentration: > 1000 nM
Compound 3: no number, only a limit (the forecaster's own chance of this, stated with the estimate: 85%); the middle value lies beyond the limit too.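

Within the data shown here, compound 1, compound 2 and compound 3 all stop at a limit of the assay in this assay, so no step between them can be read. Going by these compounds, whether furan-2-yl, 4-aminophenyl and pyridin-2-yl differ at all in this read-out stays open.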